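The source may report more compounds than this note shows. Statements on the series, on what has been measured and on what is new or still open speak of the compounds shown alone.

Compounds measured so far:
compound 1 `C=CCc1ccc(OC(=O)c2ccncc2)c(OC)c1` gives 0.86
compound 2 `C=CCc1ccc(OC(=O)c2ccccc2C)c(OC)c1` gives 2.87

In a physicochemical assay for lipophilicity (a higher number here means a more lipophilic compound, a lower number a more polar compound), compound 1 stands lowest of the two numbers; its nearest neighbour, compound 2, lies higher by a number 2.01 log units higher from compound 1 to compound 2 (beyond the scatter). Compound 3 `C=CCc1ccc(OC(=O)c2ccccc2F)c(OC)c1` has not yet been measured. The change from compound 1 to compound 3 is 2-fluorophenyl in place of pyridin-4-yl on a carbonyl carbon. Among the measured compounds shown here, the one step that bears on it is the step from compound 1 to compound 2, a number 2.01 log units higher from compound 1 to compound 2 (beyond the scatter), where a phenyl ring carrying a methyl group took the place of the pyridin-4-yl group. A fluorine-bearing phenyl ring is expected to act in the same direction, though by somewhat less, so compound 3 is expected to rise by a number 1.64 log units higher from compound 1 to compound 3 (beyond the scatter). Compound 3 is estimated at 2.5, in the range 2 to 3.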

Compound 3, partition coefficient: 2.7
Estimate against measurement, compound 3: 0.20 log units below; the measured number falls inside the stated range.
By their numbers in this assay, from the lowest: compound 1; then compounds 3 and 2 (each within the scatter of the next).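

In this assay the step to a second ortho-free wording is not needed: 2-fluorophenyl in place of pyridin-4-yl on a carbonyl carbon gives (a number 1.84 log units higher from compound 1 to compound 3 (beyond the scatter)), a large step of the same direction as the one seen with 2-methylphenyl. Fluoro in place of methyl on an aromatic carbon gives (a number 0.17 log units lower from compound 2 to compound 3 (within the scatter)), so the two substituted phenyl groups cannot be told apart here. No measurement shown bears on why these numbers fall as they do. The compounds shown leave open how a phenyl ring with no substituent, or one carrying an amine or a carboxylic acid, would read in this assay and so how much of the large steps belongs to the ring and how much to its substituent.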